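Melanocortin receptor 4 binding: aryl substituent swap on phenoxyacetamide

The source may report more compounds than this note shows. Statements on the series, on what has been measured and on what is new or still open speak of the compounds shown alone.

Measured so far:
- compound 1 `COc1ccc(OCC(=O)N2CCN(c3ccc(C(F)(F)F)cc3[C@@H](N)CC(C)C)CC2)cc1`: 3800 nM
- compound 2 `CC(C)C[C@H](N)c1cc(C(F)(F)F)ccc1N1CCN(C(=O)C(C)Cc2ccc(Cl)cc2)CC1`: 47 nM
- compound 3 `CC(C)C[C@H](N)c1cc(C(F)(F)F)ccc1N1CCN(C(=O)COc2ccc(Cl)cc2)CC1`: 2900 nM

In an assay on HEK293 cells for displacement of a labelled ligand from Melanocortin receptor 4 (Homo sapiens) (on this read-out lower numbers stand for stronger inhibition and higher numbers for weaker inhibition), compound 3 `CC(C)C[C@H](N)c1cc(C(F)(F)F)ccc1N1CCN(C(=O)COc2ccc(Cl)cc2)CC1` gives 2900 nM, the second highest of the three numbers; its nearest neighbour is compound 1 (a 1.3-fold lower number from compound 1 to compound 3 (0.12 log units; within the scatter), within the scatter), its furthest is compound 2 (a 62-fold higher number from compound 2 to compound 3 (1.79 log units; beyond the scatter), beyond it).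

Compound 4 `CC(C)C[C@H](N)c1cc(C(F)(F)F)ccc1N1CCN(C(=O)COc2ccc(O)cc2)CC1` is the next step from compound 3: hydroxy in place of chloro on an aromatic carbon. Going by the values given here, the one measured step that touches the same aromatic carbon is a 1.3-fold lower number from compound 1 to compound 3 (0.12 log units; within the scatter), which stayed within the scatter. The large steps, an 81-fold lower number from compound 1 to compound 2 (1.91 log units; beyond the scatter) and a 62-fold higher number from compound 2 to compound 3 (1.79 log units; beyond the scatter), concern the group on the carbonyl carbon, which compound 4 keeps unchanged from compound 3. Among the compounds with values here, no measured step shows what a hydroxy does at this carbon, so the expectation rests on the quiet chloro-for-methoxy exchange alone.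

For compound 4 in this assay a step of about a 1.0-fold higher number from compound 3 to compound 4 (0.01 log units; within the scatter) is therefore expected, not clearly beyond the scatter in either direction. The estimate for compound 4 is 3000 nM, with a range from 1000 nM to 9000 nM.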

Compound 4, inhibition constant: 4600 nM
For compound 4 the middle estimate is 1.5-fold (0.19 log units) below the measured one; measured number inside the range.
By their numbers in this assay, from the lowest: compound 2; then compounds 3, 1 and 4 (each within the scatter of the next).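

In this assay, hydroxy brings a hydrogen-bond donor and a hydrogen-bond acceptor to this aromatic carbon where chloro carried neither, yet the result is a 1.6-fold higher number from compound 3 to compound 4 (0.20 log units; within the scatter), and hydrogen in place of methyl on the oxygen gives a 1.2-fold higher number from compound 1 to compound 4 (0.08 log units; within the scatter), so this read-out does not separate chloro, methoxy and hydroxy at this position. The group on the carbonyl carbon remains the change that registers, with a 98-fold higher number from compound 2 to compound 4 (1.99 log units; beyond the scatter) now standing alongside the earlier large steps. No supporting evidence bears on this insensitivity to the substituent.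

As far as these compounds go, it remains open whether an amine or a carboxylic acid at this aromatic carbon would also stay within the scatter. Going by these compounds alone, it is also open whether the same insensitivity holds with the 1-(4-chlorobenzyl)ethyl group on the carbonyl carbon, since compound 2 is the only example with that group and it carries chloro.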